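This account rests on a few compounds, and the source may have more. Where it says the series, first, only, none or still open, it means among the compounds named here.

Three compounds built on closely related cores were measured in an assay on isolated protein for displacement of a labelled ligand from metabotropic glutamate receptor 5 (Homo sapiens), with a stated time of 60 min, tested at 1 uM; on this read-out higher numbers stand for more inhibition at the one concentration tested (going by the name of the read-out) and lower numbers for less inhibition. Compound 1 `CC1CCN(c2c(S(=O)(=O)c3cc(F)cc(F)c3)cnc3cc(Cl)ccc23)CC1` gives 94%. Compound 2 `CC1CCN(c2c(S(=O)(=O)c3ccc(Cl)cc3)cnc3cc(Cl)ccc23)CC1` gives 91%. Compound 3 `CC1CCN(c2c(S(=O)(=O)c3ccc(Cl)cc3)cnc3ccc(Cl)cc23)CC1` gives 92%. Compound 1 and compound 2 differ by 3,5-difluorophenyl in place of 4-chlorophenyl on a sulfonyl sulfur, and this change gave a number 3 percentage points higher from compound 2 to compound 1 (within the scatter). Compound 2 and compound 3 are made of the same atoms joined differently; the difference between the two cores is not broken down here. Compound 4 `CC1CCN(c2c(S(=O)(=O)c3cc(F)cc(F)c3)cnc3ccc(Cl)cc23)CC1` has not yet been measured and differs from compound 3 by 3,5-difluorophenyl in place of 4-chlorophenyl on a sulfonyl sulfur, the same change seen between compound 2 and compound 1. Because the earlier change gave a number 3 percentage points higher from compound 2 to compound 1 (within the scatter), the step from compound 3 to compound 4 in this assay is expected to be small, around a number 2 percentage points higher from compound 3 to compound 4 (within the scatter). Compound 4 is therefore estimated at 94%, expected to fall between 88% and 98%.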

Compound 4, a percentage reported as inhibition, at one concentration (the size of the read-out at that concentration, not a potency): 93%
The estimate for compound 4 lay 1 percentage points above the measured number, and the stated range covers the measured number.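

In this assay, putting 3,5-difluorophenyl in place of 4-chlorophenyl on a sulfonyl sulfur gave a number 1 percentage points higher from compound 3 to compound 4 (within the scatter) and so left the number within the scatter. Set beside the earlier step, the change behaves alike on both cores: the same change on two cores in this assay, a number 3 percentage points higher (within the scatter) from compound 2 to compound 1 and a number 1 percentage points higher (within the scatter) from compound 3 to compound 4, 2 percentage points apart, within the scatter of two such steps. This shows that the swap carries over between these two cores without a detectable change in inhibition at the one concentration tested, but it shows no real gain from the swap and says nothing about potency or about any other core.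

Going by these compounds, what a different kind of group on the sulfonyl sulfur, such as an amine or a carboxylic acid, would do stays open. So does whether these compounds would separate at a lower concentration.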